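Diethylamino in place of fluoro in compound 4

This account rests on a few compounds, and the source may have more. Where it says the series, first, only, none or still open, it means among the compounds named here.

Values measured so far in a functional assay on SW-620 cells (Homo sapiens) for antiproliferative activity, read by MTT assay, with a stated time of 24 h (on this read-out higher numbers stand for weaker inhibition and lower numbers for stronger inhibition), are these
Compound 1 (`COc1cccc(/C=C/C(=O)c2ccc(OC)c3c2OC(C)(C)C=C3)c1`) gives > 10000 nM as a limit
Compound 2 (`COc1ccc(/C=C/C(=O)c2ccc(OC)c3c2OC(C)(C)C=C3)c(F)c1`) gives 6570 nM as a number
Compound 3 (`COc1ccc(C(=O)/C=C/c2ccc(F)cc2)c2c1C=CC(C)(C)O2`) gives > 10000 nM as a limit

Compound 3 stands at > 10000 nM in this assay and this entry is a limit, not a number. The picture so far is thin, and its main feature is the limit of > 10000 nM in this assay, at which 2 of the 3 values shown sit, in the data.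

Compound 4 (`CCN(CC)c1ccc(/C=C/C(=O)c2ccc(OC)c3c2OC(C)(C)C=C3)cc1`) keeps the core of compound 3 and changes one group, with diethylamino in place of fluoro on an aromatic carbon. Going by the values given here, no measured step makes this exact exchange, although three steps change the group on the same chain. The first is an at least 1.5-fold lower number from compound 1 to compound 2 (0.18 log units; that floor lies within the scatter) and the second is an at least 1.5-fold higher number from compound 2 to compound 3 (0.18 log units; that floor lies within the scatter) in the data. Neither shows a size beyond the scatter. The third is a step that the two limits leave unreadable from compound 1 to compound 3 and offers no size at all.

Among the compounds with values here, the one real number comes from compound 2, which gives 6570 nM in this series, and it carries no diethylamino. From the compounds shown here alone, no step beyond the scatter is therefore expected, and the direction stays open. The estimate for compound 4 is 8000 nM as the expected value, with an expected range from 2500 nM to 20000 nM in this assay when measured. This estimate means an expected at least 1.2-fold lower number from compound 3 to compound 4 (0.09 log units; that floor lies within the scatter) in this assay.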

Compound 4, half-maximal inhibitory concentration: 670 nM
Beside the measured number, compound 4's estimate is 12-fold (1.08 log units) above it; measured number below the stated range.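

In this assay compound 3 gives > 10000 nM, which is a limit of the assay and not a number. Against that limit, putting diethylamino in place of fluoro on an aromatic carbon, para to a large group, gives an at least 14-fold lower number from compound 3 to compound 4 (1.17 log units; beyond the scatter), and this is the first step in the series that clearly exceeds the scatter of repeated measurements. It shows that this position on the ring can strongly change the read-out, something the earlier steps, each within the scatter or unreadable, could not show, although the true size remains unknown and the step gives only a minimum, as the series still rests heavily on one ceiling: the limit of > 10000 nM in this assay, at which 2 of the 4 values shown sit.

From the compounds shown here alone, what remains open is which part of the new group matters, as this single exchange brings in the nitrogen and the two ethyl chains together and removes the fluoro at the same time. A dimethylamino group, a pyrrolidine ring or a simple butyl chain on the same carbon would begin to separate these parts, and would show whether the nitrogen is needed at all.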